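The source may report more compounds than this note shows. Statements on the series, on what has been measured and on what is new or still open speak of the compounds shown alone.

Of the compounds shown here, two share a seven-membered core and have been tested in a functional assay on MCF7 cells (Homo sapiens) for antiproliferative activity; a higher number here means a weaker inhibitor, a lower number a stronger inhibitor. Compound 1 `O=[N+]([O-])c1ccc(S(=O)(=O)N2CC(n3cnc4ncnc(O)c43)OCc3ccccc32)cc1` carries a fused purine-like group on the core; in this assay compound 1 reaches only the limit of > 100000 nM, so no number is known for it. Compound 2 `O=c1cc[nH]c(=O)n1C1CN(S(=O)(=O)c2ccccc2[N+](=O)[O-])c2ccccc2CO1` carries a uracil group on the same core, and in this assay compound 2 gives 50900 nM. Among the measured compounds shown here, that is the only number among the values shown; the other value is the limit of > 100000 nM in this assay, at which 1 of the 2 values shown sits, so compound 2 cannot be placed above or below anything else on this scale.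

Compound 3 `O=c1ccn(C2CN(S(=O)(=O)c3ccccc3[N+](=O)[O-])c3ccccc3CO2)c(=O)[nH]1` is built from the same atoms as compound 2, joined differently: a group of 8 heavy atoms (4 carbon, 2 nitrogen, 2 oxygen; one six-membered aromatic ring with 2 hetero atoms) in place of a group of 8 heavy atoms (4 carbon, 2 nitrogen, 2 oxygen; one six-membered aromatic ring with 2 hetero atoms), on a saturated ring carbon. For the measured compounds named here, no measured step of this kind exists here. The expected step from compound 2 to compound 3 is a 1.2-fold higher number from compound 2 to compound 3 (0.07 log units; within the scatter), with no direction beyond the usual scatter. Compound 3 is therefore estimated at 60000 nM, in a range from 15000 nM to 200000 nM, in this assay.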

Compound 3, half-maximal inhibitory concentration: 45200 nM
Compound 3: middle estimate off by 1.3-fold (0.12 log units), on the high side; the range from low to high includes it.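

Among the compounds shown here, this is the first step that can be read at this position, the saturated ring carbon next to the ring oxygen. In this assay, joining the uracil group to the core differently, with the same atoms, gives a 1.1-fold lower number from compound 2 to compound 3 (0.05 log units; within the scatter). For this pair, then, the way the ring is attached does not separate the two compounds, and the number stays put even though the group is connected through a different atom.

Going by these compounds, compound 1 cannot join any comparison, as its result is a limit and not a number: the limit of > 100000 nM in this assay, at which 1 of the 3 values shown sits. Whether a group of another kind on this carbon, such as an amine or a carboxylic acid, would move the number beyond the scatter stays open.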